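The source may hold more compounds than are shown below. What is called first, only, known or untested is meant among the compounds shown, and "the series" means these compounds.

Among the measured compounds shown here, in an ADME assay on TZM cells (Homo sapiens) for cytotoxicity, read by XTT assay, with a stated time of 4 days (a higher number here means that more compound is tolerated, a lower number that less compound is tolerated), compound 1 `Cc1cc(C#N)cc(C)c1Oc1ccc(N)c(Nc2ccc(C#N)cc2)n1` gives 8980 nM, the only exact number so far. Compound 2 `Cc1cc(/C=C/C#N)cc(C)c1Oc1ccc([N+](=O)[O-])c(Nc2ccc(C#N)cc2)n1` reads > 48600 nM, which is a limit of the assay. Compound 3 `Cc1cc(/C=C/C#N)cc(C)c1Oc1ccc([N+](=O)[O-])c(Nc2ccc(C#N)cc2)c1` reads > 48700 nM, also a limit. For the measured compounds named here, no measured pair differs in one place, so no step is available for sizing the change. Compound 4 `C=CCc1cc(C)c(Oc2ccc(N)c(Nc3ccc(C#N)cc3)n2)c(C)c1` has allyl in place of cyano on an aromatic carbon, meta to two methyl groups and para to a large group: allyl in place of cyano on an aromatic carbon. No shift beyond the usual scatter is expected in this assay, in either direction. The estimated move is a 1.1-fold higher number from compound 1 to compound 4 (0.05 log units; within the scatter). For compound 4 the expected value is 10000 nM, with an estimated range of 3500 nM to 30000 nM.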

Compound 4, half-maximal cytotoxic concentration: 8460 nM
For compound 4 the middle estimate is 1.2-fold (0.07 log units) above the measured one, and the stated range covers the measured number.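

In this assay, among the compounds shown here, the first readable step is a 1.1-fold lower number from compound 1 to compound 4 (0.03 log units; within the scatter), for allyl in place of cyano. This position, meta to two methyl groups, therefore carries either group without a shift beyond the usual scatter, even though the exchange removes a hydrogen-bond acceptor and adds a heavy atom. Nothing measured here bears on a cause for this result.

Going by these compounds, whether a carboxylic acid or a longer chain at this position would shift the number stays open. On these data alone, this exchange also rests on a single pair, so its behaviour on other compounds remains unknown.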